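This account rests on a few compounds, and the source may have more. Where it says the series, first, only, none or still open, it means among the compounds named here.

Measured so far in an ADME assay on MT4 cells (Homo sapiens) for cytotoxicity, read by MTT assay, with a stated time of 5 days; a higher number here means that more compound is tolerated, a lower number that less compound is tolerated:

- compound 1, `COc1cc2nc(SCC(=O)Nc3ccc(C(F)(F)F)cc3)nc(Nc3c(Cl)cc(/C=C/C#N)cc3Cl)c2cc1OC`: > 197000 nM
- compound 2, `COc1cc2nc([S+]([O-])CC(=O)Nc3cccc(F)c3)nc(Nc3c(Cl)cc(/C=C/C#N)cc3Cl)c2cc1OC`: 9550 nM

The value of compound 1 in this assay is a limit of the assay and not a number. Compound 2 gives the only number shown in this assay; the other value shown is a limit (the limit of > 197000 nM in this assay, at which 1 of the 2 values shown sits). Among the compounds with values here, compounds 1 and 2 differ in more than one place, so no step between them is known; their two values show only that compound 1 sits at a limit while compound 2 sits at a number.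

Compound 3 is `COc1cc2nc([S+]([O-])CC(=O)Nc3ccc(C)cc3)nc(Nc3c(Cl)cc(/C=C/C#N)cc3Cl)c2cc1OC`. It differs from compound 2 by 4-methylphenyl in place of 3-fluorophenyl on an amide-type nitrogen. Both groups carry the same count of heavy atoms, one six-membered aromatic ring of carbon only, and no donors or acceptors. Within the data shown here, with no measured step to lean on, the expectation is a change of no more than the scatter, in no preferred direction. Compound 3 is therefore expected near 10000 nM, with a range of 3500 nM to 35000 nM. This estimate means an expected step of a 1.0-fold higher number from compound 2 to compound 3 (0.02 log units; within the scatter), none beyond the scatter.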

Compound 3, half-maximal cytotoxic concentration: 32200 nM
For compound 3 the middle estimate is 3.2-fold (0.51 log units) below the measured one, and the stated range covers the measured number.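

In this assay, within the data shown here, the group on the amide-type nitrogen gives the first single change that can be read: 4-methylphenyl in place of 3-fluorophenyl gives a 3.4-fold higher number from compound 2 to compound 3 (0.53 log units; beyond the scatter) with the sulfoxide-bearing remainder of the structure unchanged. The two groups carry the same count of heavy atoms and the same ring, so a swap that leaves those counts untouched can still move the number beyond the scatter at this position. Nothing shown gives a reason for this step.

The step swaps the group and its ring position together, so the fluorine, the methyl and the position cannot be told apart from these compounds. As far as these compounds go, how a carboxylic acid or an amine on this phenyl ring, or a cyclohexyl group in its place, would read remains open.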